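Swapping the five-membered ring on the shared core

The source may hold more compounds than are shown below. What is called first, only, known or untested is meant among the compounds shown, and "the series" means these compounds.

Measured so far:
- compound 1, `c1cncc(-c2ccccc2OCC2=NCCN2)c1`: 109%
- compound 2, `c1ccc(-c2cnccn2)c(OCC2=NCCN2)c1`: 97%
- compound 3, `c1ccc(-c2cc[nH]n2)c(OCC2=NCCN2)c1`: 119%

All three compounds were tested in a functional assay with Alpha-1A adrenergic receptor (Homo sapiens) as the target, read by calcium flux; on this read-out higher numbers stand for larger maximal responses and lower numbers for smaller maximal responses. Compound 3 gives the highest of the three numbers; its gap to compound 1 lies within the scatter, while the step from compound 2 to compound 3 is beyond it. The two steps that change the same ring are a number 12 percentage points lower from compound 1 to compound 2 (beyond the scatter) and a number 22 percentage points higher from compound 2 to compound 3 (beyond the scatter), and the step of a number 10 percentage points higher from compound 1 to compound 3 (within the scatter) stays within the scatter. So exchanging this ring has so far moved the maximal response only modestly.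

Compound 4, `c1ccc(-c2ccns2)c(OCC2=NCCN2)c1`, has not yet been measured. It differs from compound 3 by 1,2-thiazol-5-yl in place of 1H-pyrazol-3-yl on an aromatic carbon. The ring that enters keeps the same size and the same number of hetero atoms as the one that leaves, and sits ortho to a group of 7 heavy atoms, as before. Because the earlier ring exchanges gave steps no larger than a number 22 percentage points higher from compound 2 to compound 3 (beyond the scatter), a step of similar or smaller size is expected here, most likely downward toward the values of compound 1 and compound 2. For compound 4 the expected step is a number 14 percentage points lower from compound 3 to compound 4 (beyond the scatter), giving an estimated 105% with a range from 88% to 122%.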

Compound 4, largest response reached (reported as maximum), in percent of the reference or control that the assay uses: 99%
The estimate for compound 4 lay 6 percentage points above the measured number; measured number inside the range.
By their numbers in this assay, from the lowest: compounds 2, 4, 1 and 3 (each within the scatter of the next, the first and the last beyond it).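

In this assay, the exchange of 1H-pyrazol-3-yl for 1,2-thiazol-5-yl gives a number 20 percentage points lower from compound 3 to compound 4 (beyond the scatter) and shows that two five-membered aromatic rings with the same number of hetero atoms need not give the same maximal response at this place on the shared core. The new ring cannot be told apart from the two earlier rings that compound 4 is compared with here, since a number 2 percentage points higher from compound 2 to compound 4 (within the scatter) and a number 10 percentage points lower from compound 1 to compound 4 (within the scatter) both stay small enough to fall inside the usual spread of repeated measurements. The entering ring differs from the leaving one in its sulfur atom and in having 0 hydrogen-bond donors instead of 1, but no measurement at hand links either difference to the change in response.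

Every compound shown carries an aromatic ring at this place, so the effect of a non-aromatic group, such as a morpholine ring, a simple amine or a carboxylic acid, remains open. On these data alone, it is also open whether another five-membered ring, such as 1,3-thiazol-2-yl or an imidazole, would give a response closer to that of compound 3 or to that of compound 4.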